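Methoxy on the benzyl arm of the triazole amides

The source may report more compounds than this note shows. Statements on the series, on what has been measured and on what is new or still open speak of the compounds shown alone.

Going by the values given here, compound 3 `CC(C)n1ncc2c(C(=O)NCc3cn(Cc4ccccc4)nn3)cccc21` is the only member with a number in a functional assay on HepG2 cells (Homo sapiens) for inhibition, read by MTT assay, with a stated time of 72 h; a lower number here means a stronger inhibitor, a higher number a weaker inhibitor: compound 3 gives 13700 nM. Compound 1 `CC(C)n1ncc2c(C(=O)NCc3cn(-c4ccc(F)cc4)nn3)cccc21` reaches only a limit, > 40000 nM. Compound 2 `COc1ccc(-n2cc(CNC(=O)c3cccc4c3cnn4C(C)C)nn2)cc1` likewise stops at a limit, > 40000 nM. The steps of an at least 2.9-fold lower number from compound 1 to compound 3 (0.46 log units; beyond the scatter) and an at least 2.9-fold lower number from compound 2 to compound 3 (0.46 log units; beyond the scatter) are bounded by the limit of > 40000 nM in this assay, at which 2 of the 3 values shown sit. Compound 4 `COc1ccc(Cn2cc(CNC(=O)c3cccc4c3cnn4C(C)C)nn2)cc1` differs from compound 3 by methoxy in place of hydrogen on an aromatic carbon. Among the compounds with values here, the only comparison involving a methoxy group, a step that the two limits leave unreadable from compound 1 to compound 2, is unreadable, and it concerns a substituent on an aromatic nitrogen rather than a benzyl group. Within the data shown here, no measured step bears directly on the change, so in this assay the step of a 1.1-fold higher number from compound 3 to compound 4 (0.04 log units; within the scatter) is expected to stay within the scatter. Compound 4 is estimated at 15000 nM, between 5000 nM and 40000 nM.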

Compound 4, half-maximal inhibitory concentration: > 40000 nM
Compound 4 was reported as a limit; the forecaster's own chance of this, stated with the estimate: 30%; middle value at least 2.6-fold (0.42 log units) from the limit.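

Benzyl to 4-methoxybenzyl gives the first readable step on the benzyl arm in this assay: an at least 2.9-fold higher number from compound 3 to compound 4 (0.46 log units; beyond the scatter). The size of this step is bounded only, as compound 4 reaches a limit, so the measurable activity of compound 3 does not survive the added methoxy, and the series now sits mostly at one ceiling: the limit of > 40000 nM in this assay, at which 3 of the 4 values shown sit. The steps from compound 1 and from compound 2 to compound 4 cannot be read.

Going by these compounds, whether a chlorine or a hydroxyl on the benzyl ring would keep a number remains open. So does whether a longer chain in place of benzyl would.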